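The compounds below may be only part of what the source reports. "The series", "measured", "known", "first", "only" and "open" are said of these compounds alone.

Measured in a functional assay on MGC-803 cells (Homo sapiens) for inhibition, read by sulforhodamine B assay; on this read-out lower numbers stand for stronger inhibition and higher numbers for weaker inhibition:
- compound 1 `O=C1C=C(NC2CCCC2)C(=O)c2c1nc1n2[C@H]2OC[C@@H](O)[C@H]2OC1`: > 8000 nM (a limit, not a number)
- compound 2 `CCOc1ccc(NC2=CC(=O)c3nc4n(c3C2=O)[C@H]2OC[C@@H](O)[C@H]2OC4)cc1`: 1110 nM
- compound 3 `Cc1ccc(NC2=CC(=O)c3nc4n(c3C2=O)[C@H]2OC[C@@H](O)[C@H]2OC4)cc1C`: 860 nM

Compound 3 and compound 2 sit level, as a 1.3-fold lower number from compound 2 to compound 3 (0.11 log units; within the scatter) shows. Compound 1 has only a limit, so the series offers just these two numbers.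

The next compound is compound 4 `Cc1ccc(NC2=CC(=O)c3nc4n(c3C2=O)[C@H]2OC[C@@H](O)[C@H]2OC4)cc1`, which takes 3,4-dimethylphenyl to 4-methylphenyl: hydrogen in place of methyl on an aromatic carbon. In words, hydrogen replaces methyl on an aromatic carbon, ortho to a methyl group and meta to a large group.

For the measured compounds named here, no measured step matches this change exactly. The closest is the exchange of one substituted phenyl for another, a 1.3-fold lower number from compound 2 to compound 3 (0.11 log units; within the scatter), which stays within the scatter. The larger steps leave cyclopentyl for a substituted phenyl: an at least 7.2-fold lower number from compound 1 to compound 2 (0.85 log units; beyond the scatter), and an at least 9.3-fold lower number from compound 1 to compound 3 (0.96 log units; beyond the scatter). Compound 4 keeps a substituted phenyl on the amine nitrogen, so those larger steps are not repeated here.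

In this assay, no change beyond the scatter is expected, with no firm direction. The expected move is a 1.2-fold higher number from compound 3 to compound 4 (0.07 log units; within the scatter). For compound 4, the estimated value is 1000 nM, with an expected range from 500 nM to 2200 nM.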

Compound 4, half-maximal inhibitory concentration: 1420 nM
Estimate against measurement, compound 4: 1.4-fold (0.15 log units) below, and the stated range covers the measured number.
By their numbers in this assay, from the lowest: compounds 3, 2 and 4 (each within the scatter of the next). At a limit, above all of these: compound 1.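

In this assay, hydrogen in place of methyl on the aromatic carbon ortho to a methyl group and meta to a large group gives a 1.7-fold higher number from compound 3 to compound 4 (0.22 log units; within the scatter), so at this position the methyl can go without a change beyond the scatter. The 4-methylphenyl group also cannot be told apart from 4-ethoxyphenyl, with a 1.3-fold higher number from compound 2 to compound 4 (0.11 log units; within the scatter), which leaves the three substituted phenyl groups level, while an at least 5.6-fold lower number from compound 1 to compound 4 (0.75 log units; beyond the scatter) sets 4-methylphenyl apart from cyclopentyl, as the other two substituted phenyl groups already were. For compound 1 the figure is a limit and not a number: the limit of > 8000 nM in this assay, at which 1 of the 4 values shown sits.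

Still open, on these data alone, is whether any group on this aromatic ring can move the number beyond the scatter, as the three substituted phenyl groups carry only methyl or ethoxy, and an unsubstituted phenyl, a chlorine, an amine or a carboxylic acid would test that. As far as these compounds go, the true size of the gap to cyclopentyl also remains unknown, and no other saturated ring on the amine nitrogen, such as cyclohexyl, is available to show whether that gap belongs to cyclopentyl alone.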